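A few compounds are considered here, and "the series" means these few. Any claim that something is new, unique, unknown or untested is made for them only; others in the source may bear on it.

Values in a functional assay on U-266 cells (Homo sapiens) for inhibition, read by MTT assay, with a stated time of 48 h, tested at 0.1 uM; a lower number here means less inhibition, a higher number more inhibition at the concentration tested (going by the name of the read-out):

compound 1, `Cc1noc(C)c1-c1ccc2c(c1)C(c1ccccc1)NC(=O)N2C`: 13.1%
compound 2, `Cc1noc(C)c1-c1ccc2c(c1)C(c1ccccc1)N(Cc1nnc(-c3ccccc3)o1)C(=O)N2C`: 26.7%
compound 3, `Cc1noc(C)c1-c1ccc2c(c1)C(c1ccccc1)N(Cc1ncc(-c3ccccc3)o1)C(=O)N2C`: 15.1%

Compound 3 stands second highest of the three numbers in this assay. Its nearest neighbour is compound 1, and the step of a number 2 percentage points higher from compound 1 to compound 3 (within the scatter) lies within the scatter, so no order between compound 1 and compound 3 is read from it. Compound 2 is furthest away; the step of a number 11.6 percentage points lower from compound 2 to compound 3 (beyond the scatter) lies beyond the scatter and is modest in size.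

Compound 4, `Cc1nc(-c2ccccc2)sc1CN1C(=O)N(C)c2ccc(-c3c(C)noc3C)cc2C1c1ccccc1`, differs from compound 3 in one place: 4-methyl-2-phenyl-1,3-thiazol-5-yl in place of 5-phenyl-1,3-oxazol-2-yl on a saturated chain carbon bound to an amide-type nitrogen in a ring. The measured step that bears most on this change is a number 11.6 percentage points lower from compound 2 to compound 3 (beyond the scatter), an exchange of one five-membered aromatic ring for another at the same saturated chain carbon, which gave a modest shift. The step of a number 13.6 percentage points higher from compound 1 to compound 2 (beyond the scatter) tells only what adding a ring-bearing chain to the hydrogen-bearing nitrogen of compound 1 gave. Among the compounds with values here, no measured compound carries the entering 4-methyl-2-phenyl-1,3-thiazol-5-yl group, so the direction is not fixed by the data; a step of modest size at most is expected, and the estimated step is a number 2.9 percentage points higher from compound 3 to compound 4 (within the scatter). Compound 4 is therefore expected at 18%, with a range from 7% to 31%.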

Compound 4, a percentage reported as inhibition, at one concentration (the size of the read-out at that concentration, not a potency): 7.19%
Estimate against measurement, compound 4: 10.8 percentage points above; the range from low to high includes it.
By their numbers in this assay, from the lowest: compounds 4, 1 and 3 (each within the scatter of the next); then compound 2.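

In this assay the exchange at the saturated chain carbon gives a number 7.9 percentage points lower from compound 3 to compound 4 (within the scatter), so the 4-methyl-2-phenyl-1,3-thiazol-5-yl and 5-phenyl-1,3-oxazol-2-yl groups are not told apart at this position. The other new step, a number 19.5 percentage points lower from compound 2 to compound 4 (beyond the scatter), lies beyond the scatter, and compound 2 now stands clear of all three other compounds, including compound 1, which carries only hydrogen on the amide-type nitrogen; of the three ring groups shown at this place, only 5-phenyl-1,3,4-oxadiazol-2-yl gives a number separated from that of compound 1. No measurement at hand accounts for this difference between the ring groups.

Compound 4 changes the ring and adds a methyl group in one step, so the compounds shown do not separate the two changes, and 2-phenyl-1,3-thiazol-5-yl without the methyl group would be the direct test. From the compounds shown here alone, it also remains open whether the number of compound 2 holds when the phenyl on the 1,3,4-oxadiazole is exchanged for a carboxylic acid or an amine, or when a longer chain carries the ring.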